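The source may report more compounds than this note shows. Statements on the series, on what has been measured and on what is new or still open speak of the compounds shown alone.

Compound 1 `O=C(CCc1cccc2c1B(O)OC2)NC1CCCCC1`: > 100000 nM (a limit of the assay, not a number)
Compound 2 `O=C(CCc1cccc2c1B(O)OC2)Nc1ccc(Cl)cc1`: 3600 nM

Both compounds were tested in a functional assay on MDA-MB-231 cells (Homo sapiens) for antiproliferative activity, read by MTT assay, with a stated time of 72 h; a lower number here means a stronger inhibitor, a higher number a weaker inhibitor. Only compound 2 has a true number there, so it is the single firm reference point. Compound 3 `O=C(CCc1cccc2c1B(O)OC2)Nc1ccc(Br)cc1` differs from compound 2 at one place: bromo in place of chloro on an aromatic carbon. In words, this is bromo in place of chloro on an aromatic carbon, para to a large group.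

For the measured compounds named here, only one measured step bears on this change: an at least 27-fold lower number from compound 1 to compound 2 (1.44 log units; beyond the scatter). That large step replaced the whole group on the amide-type nitrogen, whereas compound 3 exchanges one halogen atom for another. Going by the values given here, no measured step shows such an exchange, so the large size does not carry over. The expected result is a 1.2-fold lower number from compound 2 to compound 3 (0.08 log units; within the scatter), which would lie within the scatter, with no clear direction. For compound 3, the estimated value is 3000 nM, with an expected range of 1200 nM to 8000 nM.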

Compound 3, half-maximal inhibitory concentration: 5300 nM
The estimate for compound 3 lay 1.8-fold (0.25 log units) below the measured number; the measured number falls inside the stated range.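

Exchanging chloro for bromo on the aromatic carbon gives a 1.5-fold higher number from compound 2 to compound 3 (0.17 log units; within the scatter), so in this assay the two halogens cannot be told apart at this position. The advantage over cyclohexyl on the amide-type nitrogen also appears with a second halogen, with an at least 18-fold lower number from compound 1 to compound 3 (1.27 log units; beyond the scatter), so it is not confined to the 4-chlorophenyl group. That step gives only a minimum size, because compound 1 stands at a limit of the assay rather than at a true number: the limit of > 100000 nM in this assay, at which 1 of the 3 values shown sits.

From the compounds shown here alone, it remains open whether this position needs a halogen at all, since a fluoro group, a methoxy group, an amine or a plain phenyl could give a very different number. Also open, going by these compounds, is how a longer chain on the shared core would affect the number.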